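Working notes: the step from compound 2 to compound 3

A few compounds are considered here, and "the series" means these few. Any claim that something is new, unique, unknown or untested is made for them only; others in the source may bear on it.

Measured in a physicochemical assay, read by spectrophotometry, with a stated time of 6 min; on this read-out lower numbers stand for stronger inhibition and higher numbers for weaker inhibition:
- compound 1 `O=C(CCc1nc2ccccc2c(=O)[nH]1)N/N=C/c1ccc(O)c(O)c1`: 40000000 nM
- compound 2 `COc1cc(/C=N/NC(=O)CCc2nc3ccccc3c(=O)[nH]2)ccc1O`: 95000000 nM

Within the data shown here, compound 2 holds the higher of the two numbers in this assay, and its only neighbour is compound 1. The next compound is compound 3 `COc1ccc(/C=N/NC(=O)CCc2nc3ccccc3c(=O)[nH]2)cc1`, not yet measured: 4-methoxyphenyl in place of 4-hydroxy-3-methoxyphenyl on a carbon with a double bond to nitrogen. In words, 4-methoxyphenyl stands in place of 4-hydroxy-3-methoxyphenyl on a carbon with a double bond to nitrogen.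

Among the measured compounds shown here, no measured step covers this exact change. The closest is a 2.4-fold higher number from compound 1 to compound 2 (0.38 log units; beyond the scatter), where a methyl replaced a hydrogen on an oxygen on the aromatic ring. That step also took away a hydroxy group, so it bears on this change only in part. A similarly modest step toward a higher number is therefore expected, though with wide uncertainty from a single precedent. The expected move is a 1.8-fold higher number from compound 2 to compound 3 (0.25 log units; within the scatter). For compound 3 the estimated value is 170000000 nM, with an expected range of 60000000 nM to 450000000 nM.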

Compound 3, half-maximal inhibitory concentration: 75000000 nM
Compound 3: middle estimate off by 2.3-fold (0.36 log units), on the high side; the range from low to high includes it.
By their numbers in this assay, from the lowest: compounds 1, 3 and 2 (each within the scatter of the next, the first and the last beyond it).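

In this assay, a 1.3-fold lower number from compound 2 to compound 3 (0.10 log units; within the scatter), so replacing 4-hydroxy-3-methoxyphenyl with 4-methoxyphenyl on the carbon with a double bond to nitrogen gives no resolved difference, even though the group that enters has 0 hydrogen-bond donors. Among these compounds, likewise, a 1.9-fold higher number from compound 1 to compound 3 (0.27 log units; within the scatter), which leaves a 2.4-fold higher number from compound 1 to compound 2 (0.38 log units; beyond the scatter) as the only step of the three beyond the scatter, and the series so far shows only a modest sensitivity to this aromatic group. No supporting data are available to explain these numbers.

From the compounds shown here alone, the three compounds differ only in the hydroxy and methoxy groups on this aromatic ring, so it remains open whether an amine or a carboxylic acid there would move the number beyond the scatter. Going by these compounds, the effect of a longer chain in place of the methyl on oxygen, and of any change to the shared core, also remains open.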